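Thiophene-to-furan swap on the amino-bearing core

The compounds below may be only part of what the source reports. "The series", "measured", "known", "first", "only" and "open" are said of these compounds alone.

Compound 1 `OC[C@H]1O[C@@H](n2cnc3c(-c4cccs4)ncnc32)C[C@@H]1O` and compound 2 `Nc1nc(-c2cccs2)c2ncn([C@H]3C[C@H](O)[C@@H](CO)O3)c2n1` share the same core and sugar and differ only by the amino group. In a functional assay on HT-1080 cells (Homo sapiens), read by MTT assay (on this read-out lower numbers stand for stronger inhibition and higher numbers for weaker inhibition), compound 1 gives 95000 nM, and compound 2 gives 38000 nM. Going by the values given here, the one measured step, a 2.5-fold lower number from compound 1 to compound 2 (0.40 log units; beyond the scatter), leaves compound 2 with the lowest of the two numbers.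

Compound 3 `Nc1nc(-c2ccco2)c2ncn([C@H]3C[C@H](O)[C@@H](CO)O3)c2n1` carries furan-2-yl in place of thiophen-2-yl on an aromatic carbon. Among the compounds with values here, no measured step touches this ring: the only step known, the amino change from compound 1 to compound 2, concerns a different group and says nothing about a ring swap. Both groups match in size and in what they count, so the expected step is a 1.1-fold higher number from compound 2 to compound 3 (0.02 log units; within the scatter), that is none beyond the scatter, with wide uncertainty. In this assay compound 3 is estimated at 40000 nM, within a range of 14000 nM to 115000 nM.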

Compound 3, half-maximal inhibitory concentration: 290000 nM
Compound 3: the middle estimate sits 7.3-fold (0.86 log units) below what was measured; the whole stated range lies below it.
By their numbers in this assay, from the lowest: compound 2; then compound 1; then compound 3.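

In this assay the swap of thiophen-2-yl for furan-2-yl gives a 7.6-fold higher number from compound 2 to compound 3 (0.88 log units; beyond the scatter), so this aromatic carbon next to the ring nitrogen is sensitive to the ring it carries, which the amino change alone could not show. The two rings match in heavy-atom count, in hydrogen-bond donors and acceptors and in charge, and they differ in the ring hetero atom, sulfur against oxygen, so matching counts are a poor guide at this position. Nothing available explains why the oxygen ring gives the higher number.

Still open, from the compounds shown here alone, is how other groups at this carbon, such as phenyl, thiophen-3-yl or a simple amine, would compare with thiophen-2-yl. Also open, going by these compounds, is whether furan-2-yl would shift the number in the same direction on the core of compound 1, which lacks the amino group.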